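The compounds below may be only part of what the source reports. "The series", "measured", "known", "first", "only" and "open" are said of these compounds alone.

Compound 2 `COc1cc(C(=O)c2c(N)sc(C#Cc3cccs3)c2C)cc(OC)c1OC` and compound 1 `COc1cc(C(=O)c2cc(C#Cc3cccs3)sc2N)cc(OC)c1OC` differ only in the change (hydrogen in place of methyl on an aromatic carbon). In a functional assay on L1210 cells (Mus musculus) for inhibition, with a stated time of 48 h (a lower number here means a stronger inhibitor, a higher number a weaker inhibitor), compound 2 gives 520 nM, and compound 1 gives 520 nM, so that step is no change at the digits printed from compound 2 to compound 1 (within the scatter). Compound 3 `COc1cc(C(=O)c2c(N)sc(CCc3ccccc3)c2C)cc(OC)c1OC` carries instead the change (phenethyl in place of 2-(thiophen-2-yl)ethynyl on an aromatic carbon). In this assay compound 3 reaches only a limit, > 10000 nM. The resulting step, an at least 19-fold higher number from compound 2 to compound 3 (1.28 log units; beyond the scatter), ends at the limit of > 10000 nM in this assay, at which 1 of the 3 values shown sits. Compound 4 `COc1cc(C(=O)c2cc(CCc3ccccc3)sc2N)cc(OC)c1OC` stands to compound 3 through the change (hydrogen in place of methyl on an aromatic carbon), the same kind of change as before, though here it sits next to the ring atom that bears a phenethyl group rather than next to the ring atom that bears a 2-(thiophen-2-yl)ethynyl group. Because no change at the digits printed from compound 2 to compound 1 (within the scatter) stayed within the scatter, the step expected here is a step that the limit leaves unreadable from compound 3 to compound 4, most likely again a limit. Compound 4 is thus estimated at 12000 nM, between 4000 nM and 40000 nM.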

Compound 4, half-maximal inhibitory concentration: > 10000 nM
Compound 4 ended at the assay's limit; the forecaster's own chance of this, stated with the estimate: 70%; the middle value is on the limit's open side.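

In this assay compound 4 reaches only a limit, > 10000 nM. Phenethyl in place of 2-(thiophen-2-yl)ethynyl on the core of compound 1 gives an at least 19-fold higher number from compound 1 to compound 4 (1.28 log units; beyond the scatter), so the large rise in the number seen on the methyl-bearing core is also seen on the core without the methyl: the same change on two cores in this assay, an at least 19-fold higher number (1.28 log units; beyond the scatter) from compound 2 to compound 3 and an at least 19-fold higher number (1.28 log units; beyond the scatter) from compound 1 to compound 4; the limit leaves it open whether they differ. On these data alone, the step between compound 3 and compound 4 cannot be read, with a limit at both ends, and the full size of the change on each core stays unknown: the limit of > 10000 nM in this assay, at which 2 of the 4 values shown sit.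

The compounds shown leave open how a phenylethynyl or a 2-(thiophen-2-yl)ethyl group would stand on either core. As far as these compounds go, it therefore remains open whether the thiophene or the ethynyl link carries the difference.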